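This account rests on a few compounds, and the source may have more. Where it says the series, first, only, none or still open, it means among the compounds named here.

Compound 1 (`Cc1c(Cc2c(F)cccc2F)nc(SCc2ccccc2)[nH]c1=O`) gives > 70000 nM in an ADME assay on MT4 cells (Homo sapiens) for cytotoxicity, read by MTT assay (a lower number here means that less compound is tolerated, a higher number that more compound is tolerated), as its reading, and this is a limit, not a number. Compound 2 (`Cc1cc(C)cc(CSc2nc(Cc3c(F)cccc3F)c(C)c(=O)[nH]2)c1`) gives > 65000 nM in this assay as its reading, again a limit. Compound 3 (`Cc1c(Cc2c(F)cccc2F)nc(SCc2ccccn2)[nH]c1=O`) gives > 70000 nM in this assay as its reading, also a limit. Compound 3 thus stands with compound 1 at the limit of > 70000 nM in this assay, at which 2 of the 3 values shown sit, in this small set, while compound 2 stands at the limit of > 65000 nM in this assay, at which 1 of the 3 values shown sits, on its own.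

Compound 4 (`Cc1c(Cc2c(F)cccc2F)nc(SCc2cccnc2)[nH]c1=O`) has the same atoms as compound 3, joined differently (pyridin-3-yl in place of pyridin-2-yl on a saturated chain carbon bound to a sulfur) with pyridin-3-yl in place of pyridin-2-yl on a saturated chain carbon bound to a sulfur.

The measured steps at this same place are a step that the two limits leave unreadable from compound 1 to compound 3 and a step that the two limits leave unreadable from compound 2 to compound 3 and a step that the two limits leave unreadable from compound 1 to compound 2 and none of them has a size that can be read. They offer no sign of a change at this place, so no step beyond the scatter is expected, and no direction is expected either. The expected change is a number no higher from compound 3 to compound 4 (the limit leaves the size open) in this estimate. Compound 4 is estimated at 70000 nM in this assay with an expected range from 35000 nM to 140000 nM and it will probably be reported only as a limit.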

Compound 4, half-maximal cytotoxic concentration: > 70000 nM
Compound 4: only a limit was reported; the forecaster's own chance of this, stated with the estimate: 80%; the middle value sits exactly at the limit.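

In this assay compound 4 gives > 70000 nM, and this is a limit, not a number. Among the compounds shown here, the readings of compound 1, compound 2 and compound 3 are limits too, so no step to compound 4 can be read. The compounds shown leave open whether phenyl, 3,5-dimethylphenyl, pyridin-2-yl and pyridin-3-yl at this place differ at all in this assay.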